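Benzyloxy in place of methoxy on a flat series

The source may hold more compounds than are shown below. What is called first, only, known or untested is meant among the compounds shown, and "the series" means these compounds.

Of the compounds shown here, three have been tested in a functional assay for inhibition, tested at 0.1 mM; a lower number here means less inhibition, a higher number more inhibition at the concentration tested (going by the name of the read-out). Compound 1 `CNc1nnc(Cn2c(-c3ccc(OC)cc3)nc3ccccc32)s1` gives 5% in this assay. Compound 2 `COc1ccc(-c2nc3ccccc3n2Cc2n[nH]c(=S)n2C)cc1` gives 5% in this assay. Compound 3 `CNc1nnc(Cn2c(-c3ccc(O)cc3)nc3ccccc32)s1` gives 5% in this assay. The step of no change at the digits printed from compound 1 to compound 2 (within the scatter) and the step of no change at the digits printed from compound 1 to compound 3 (within the scatter) both leave the read-out where it was, so compound 2 stands level with compounds 1 and 3 on the numbers shown.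

Compound 4 `Cn1c(Cn2c(-c3ccc(OCc4ccccc4)cc3)nc3ccccc32)n[nH]c1=S` is the next member and is not yet measured in this assay. It differs from compound 2 in one place: phenyl in place of hydrogen on a saturated chain carbon bound to an oxygen on an aromatic ring. Among the measured compounds shown here, no measured step alters exactly this position. For the measured compounds named here, the nearest precedent is the step of no change at the digits printed from compound 1 to compound 3 (within the scatter), which exchanges methyl for hydrogen on the oxygen on the aromatic ring and stays within the scatter. Every measured change in this assay has been flat, and the read-out of compound 2 already sits low. The step of a number 3 percentage points higher from compound 2 to compound 4 (within the scatter) is therefore expected to stay within the scatter. Compound 4 is estimated at 8% in this assay, in the range 0% to 25%.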

Compound 4, a percentage reported as inhibition, at one concentration (the size of the read-out at that concentration, not a potency): 5%
For compound 4 the middle estimate is 3 percentage points above the measured one, within the range that was stated.
By their numbers in this assay, from the lowest: compounds 1, 2, 3 and 4 (each within the scatter of the next).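

In this assay the methoxy to benzyloxy change gives no change at the digits printed from compound 2 to compound 4 (within the scatter), so the series now stays flat at this oxygen with a phenyl-bearing group as well as with the methyl and hydrogen compared earlier. This extends the flat picture from a small exchange on the oxygen to a much larger one, but with compound 4 at 5%, the result shows only that phenyl at this place brings no gain in the read-out at the single concentration tested, and it says nothing about potency. Nothing available explains this flat result.

As far as these compounds go, it remains open whether any group at this place can move the read-out, for example a longer chain such as phenethyl, or a benzyl carrying an amine or a carboxylic acid. From the compounds shown here alone, the benzyloxy group on the core of compound 1, with its different group on the saturated chain carbon, also remains open.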